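Swapping cyclohexyl for phenyl in a weakly antiproliferative sulfonamide

This account rests on a few compounds, and the source may have more. Where it says the series, first, only, none or still open, it means among the compounds named here.

This account concerns two measured sulfonamides and an unmeasured one that awaits testing. Compound 1 `Cc1ccc(S(=O)(=O)N2CC[C@@H](Cl)C[C@@H]2c2ccccc2)cc1` carries a chloro group and a phenyl on its saturated ring. In a functional assay on SW1573 cells (Homo sapiens) for antiproliferative activity, read by sulforhodamine B assay, with a stated time of 48 h (a lower number here means a stronger inhibitor of growth, a higher number a weaker inhibitor of growth), compound 1 gives > 100000 nM, which is a limit of the assay rather than a number. Compound 2 `Cc1ccc(S(=O)(=O)N2CC[C@@H](Br)C[C@@H]2C2CCCCC2)cc1` carries a bromo group and a cyclohexyl in place of the phenyl; in this assay compound 2 gives 82000 nM. Among the values shown, that of compound 2 is the only actual number, the other being a limit (the limit of > 100000 nM in this assay, at which 1 of the 2 values shown sits). Compound 3 `Cc1ccc(S(=O)(=O)N2CC[C@@H](Br)C[C@@H]2c2ccccc2)cc1` is the target of the next step: relative to compound 2 it has phenyl in place of cyclohexyl on a saturated ring carbon, phenyl in place of cyclohexyl on a saturated ring carbon. Among the compounds with values here, no step between measured compounds is available to anchor this change, and the evidence shows only that compound 1, which also bears a phenyl there, sits at the limit. The expectation for compound 3 is therefore a small step toward weaker growth inhibition, a 1.3-fold higher number from compound 2 to compound 3 (0.13 log units; within the scatter), within or just beyond the scatter. The estimate for compound 3 is 110000 nM, within a range from 40000 nM to 300000 nM, with a real chance that only a limit is reported.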

Compound 3, concentration for 50% growth inhibition: > 100000 nM
Compound 3 was reported as a limit; the forecaster's own chance of this, stated with the estimate: 55%; the middle value lies beyond the limit too.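

The step from cyclohexyl to phenyl on a saturated ring carbon can now be read directly with the bromo group held constant in this assay, and it is an at least 1.2-fold higher number from compound 2 to compound 3 (0.08 log units; that floor lies within the scatter). Compound 3 is reported only as a limit, so this is a floor rather than a measured size: it shows that the phenyl brings no gain in growth inhibition over the cyclohexyl, but the true step may be small or much larger. With the phenyl in place, compound 1 and compound 3 both stand as limits, so the step from chloro to bromo cannot be read, and the only actual number remains the one carrying cyclohexyl: the limit of > 100000 nM in this assay, at which 2 of the 3 values shown sit.

The compounds shown leave open whether the cyclohexyl would give a measurable number with chloro in place of bromo, which would separate the two changes that distinguish compound 1 from compound 2. Also open, as far as these compounds go, is whether an amine or a carboxylic acid in place of the bromo group, or a longer chain in place of the cyclohexyl, would give a clearly lower number than compound 2 gives at 82000 nM.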